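The source may hold more compounds than are shown below. What is called first, only, known or untested is meant among the compounds shown, and "the series" means these compounds.

Three compounds have been measured in a functional assay on U2OS cells for antagonist activity at C-X-C chemokine receptor type 3 (Homo sapiens), read by beta-arrestin recruitment; a higher number here means a weaker inhibitor, a lower number a stronger inhibitor:

Compound 1, `CC[C@@H]1CN(c2scnc2-c2nc3ccccc3[nH]2)CCN1C(=O)Cn1cnc2cccnc21`, gives 604 nM.
Compound 2, `Cc1nc(-c2nc3ccccc3[nH]2)c(N2CCN(C(=O)Cn3cnc4cccnc43)[C@H](C)C2)s1`, gives 1050 nM.
Compound 3, `CCOc1ncc(-c2nc(C(F)(F)F)sc2N2CCN(C(=O)Cn3ccc4cnccc43)[C@H](C)C2)cn1`, gives 23 nM.

Compound 3 has the lowest of the three numbers, so it is the strongest inhibitor of the set. The nearest other number, that of compound 1, lies beyond the usual scatter above it, and the number of compound 2 lies further away still. The gap between compound 1 and compound 2 is also beyond the scatter.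

Compound 4, `CCOc1ncc(-c2nc(C(F)(F)F)sc2N2CCN(C(=O)Cn3nc(C)cc3C)[C@H](C)C2)cn1`, is not yet measured. It differs from compound 3 in one place: a group of 7 heavy atoms (5 carbon, 2 nitrogen; one five-membered aromatic ring with 2 hetero atoms) in place of a group of 9 heavy atoms (7 carbon, 2 nitrogen; one five-membered aromatic ring with 1 hetero atom, one six-membered aromatic ring with 1 hetero atom), on a saturated chain carbon bound to a carbonyl carbon. The part that is swapped is the ring system carried by the chain that hangs from the carbonyl, while the shared core of compound 3 is kept unchanged.

Within the data shown here, no pair of measured compounds shows this kind of swap, so its effect is not known from the data. The smaller ring is expected to hold a weaker grip, giving a modest rise in the number in this assay, likely beyond the scatter but not a large one. The step from compound 3 to compound 4 is therefore expected to be a 3.0-fold higher number from compound 3 to compound 4 (0.48 log units; beyond the scatter). For compound 4 the estimate in this assay is 70 nM, with a range from 20 nM to 300 nM.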

Compound 4, half-maximal inhibitory concentration: 87 nM
The estimate for compound 4 lay 1.2-fold (0.09 log units) below the measured number; the measured number falls inside the stated range.
By their numbers in this assay, from the lowest: compound 3; then compound 4; then compounds 1 and 2 (each within the scatter of the next).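

In this assay, putting 3,5-dimethyl-1H-pyrazol-1-yl in place of the larger group with its five-membered and six-membered aromatic rings gives a 3.8-fold higher number from compound 3 to compound 4 (0.58 log units; beyond the scatter) and a weaker inhibitor, but this is a modest step. On this saturated chain carbon bound to a carbonyl carbon, then, a single five-membered aromatic ring can replace the two-ring group while compound 4 still reaches 87 nM in this assay. The two groups have matching counts of hydrogen-bond donors and acceptors, and no separate measurement explains the rise in the number.

Among these compounds, with only this one swap at the position, it remains open how much the two methyl groups contribute. A pyrazole without methyl groups, one carrying ethyl groups, or a plain phenyl ring in the same place could help to answer that.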